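The compounds below may be only part of what the source reports. "The series", "measured", "known", "first", "only" and "open" are said of these compounds alone.

Working notes on the series in an ADME assay on MT4 cells (Homo sapiens) for cytotoxicity, read by MTT assay; on this read-out higher numbers stand for lower toxicity in this test and lower numbers for higher toxicity in this test. All three measured compounds share one core and differ only in the substituent on the carboxamide nitrogen. Compound 1 `Cc1cc(C)cc(S(=O)(=O)c2c(C(=O)NCc3cccc(N)c3)[nH]c3ccc(Cl)cc23)c1` reaches only a limit of the assay in this assay, > 53400 nM. Compound 2 `Cc1cc(C)cc(S(=O)(=O)c2c(C(=O)NC(C)C(=O)NC(C)c3ccncc3)[nH]c3ccc(Cl)cc23)c1` gives 21900 nM in this assay. Compound 3 `Cc1cc(C)cc(S(=O)(=O)c2c(C(=O)NCC(=O)NC(C)c3ccncc3)[nH]c3ccc(Cl)cc23)c1` gives 47000 nM in this assay, the highest of the two numbers obtained; the nearest number is that of compound 2, and the step of a 2.1-fold higher number from compound 2 to compound 3 (0.33 log units; beyond the scatter) runs beyond the scatter. The step of an at least 1.1-fold lower number from compound 1 to compound 3 (0.05 log units; that floor lies within the scatter) rests at a floor within the scatter because compound 1 sits at the limit of > 53400 nM in this assay, at which 1 of the 3 values shown sits.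

Compound 4 `Cc1cc(C)cc(S(=O)(=O)c2c(C(=O)Nc3cc(C#N)ccn3)[nH]c3ccc(Cl)cc23)c1` differs from compound 3 by a group of 8 heavy atoms (6 carbon, 2 nitrogen; one six-membered aromatic ring with 1 hetero atom) in place of a group of 12 heavy atoms (9 carbon, 2 nitrogen, 1 oxygen; one six-membered aromatic ring with 1 hetero atom), on an amide-type nitrogen. Of the measured steps, only an at least 1.1-fold lower number from compound 1 to compound 3 (0.05 log units; that floor lies within the scatter) changes the group on the amide nitrogen and it stays at a floor within the scatter, whereas a 2.1-fold higher number from compound 2 to compound 3 (0.33 log units; beyond the scatter) alters a chain carbon and is modest. Going by the values given here, no measured step reaches the aryl-type amide substituent of compound 4 directly.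

The step of a 1.2-fold lower number from compound 3 to compound 4 (0.07 log units; within the scatter) is expected to lie within the scatter or close to it. Compound 4 is estimated at 40000 nM, within the range 15000 nM to 90000 nM.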

Compound 4, half-maximal cytotoxic concentration: > 53700 nM
Compound 4 ended at the assay's limit; the forecaster's own chance of this, stated with the estimate: 30%; middle value at least 1.3-fold (0.12 log units) from the limit.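

In this assay compound 4 gives > 53700 nM, which is a limit of the assay and not a number. On the amide-type nitrogen, the change to 4-cyanopyridin-2-yl, a group of 8 heavy atoms in place of the group of 12 heavy atoms, gives an at least 1.1-fold higher number from compound 3 to compound 4 (0.05 log units; that floor lies within the scatter), so the series now shows that this much smaller substituent, with its ring bound directly to the amide-type nitrogen, brings no measurable fall in the number, though a real rise cannot be claimed from a floor within the scatter. The step between compound 1 and compound 4 cannot be read, since each side is a limit, and the two substituents, 3-aminobenzyl and 4-cyanopyridin-2-yl, can only be said to share the same kind of result in this test.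

The compounds shown leave open how far compound 1 and compound 4 actually lie from compound 3, and so whether any substituent on this nitrogen separates from the others beyond the scatter. They also leave open whether the nitrile itself matters, which a plain pyridin-2-yl or a carboxylic acid in its place would address.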